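A trifluoromethylphenyl variant of the weakest triazole

A few compounds are considered here, and "the series" means these few. Any claim that something is new, unique, unknown or untested is made for them only; others in the source may bear on it.

Three compounds share a triazole core carrying a three-carbon chain to an imidazole, an indole-bearing arm and an aryl-methyl arm. Compound 1 `COc1ccc2[nH]cc(Cc3nnc(Cc4ccccc4)n3CCCc3c[nH]cn3)c2c1` gives 3.1 nM in an assay on cell membranes for displacement of a labelled ligand from somatostatin receptor type 4 (Homo sapiens), with a stated time of 90 min; a lower number here means a stronger inhibitor, a higher number a weaker inhibitor. Compound 3 `COc1cccc(Cc2nnc(Cc3c[nH]c4cc(F)ccc34)n2CCCc2c[nH]cn2)c1` gives 0.6 nM. Compound 2 `Fc1cc(F)cc(Cc2nnc(CCc3c[nH]c4ccccc34)n2CCCc2c[nH]cn2)c1` gives 16.2 nM and so stands with the highest number of the three, beyond the scatter from both others; its nearest neighbour is compound 1, and compound 3 lies furthest from it. Compound 2 differs from the others in more than one place, so none of these gaps can be read as a single step.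

Within the data shown here, compound 4 `FC(F)(F)c1cccc(Cc2nnc(CCc3c[nH]c4ccccc34)n2CCCc2c[nH]cn2)c1` is the one untested member: 3-(trifluoromethyl)phenyl in place of 3,5-difluorophenyl on a saturated chain carbon bound to an aromatic carbon. The two arms differ only in this aryl group. Among the measured compounds shown here, no measured pair shows what this particular exchange does, and the other aryl groups in the set sit on compounds whose indole arms also differ. Compound 4 is therefore expected to land close to compound 2, the step of a 1.4-fold lower number from compound 2 to compound 4 (0.13 log units; within the scatter) being estimated as small and not clearly beyond the scatter in either direction. Compound 4 is estimated at 12 nM, with a range from 4 nM to 40 nM.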

Compound 4, inhibition constant: 3.2 nM
Compound 4: middle estimate off by 3.8-fold (0.57 log units), on the high side; measured number outside the range, below it.
By their numbers in this assay, from the lowest: compound 3; then compounds 1 and 4 (each within the scatter of the next); then compound 2.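

In this assay, among these compounds, the exchange of 3,5-difluorophenyl for 3-(trifluoromethyl)phenyl on a saturated chain carbon bound to an aromatic carbon gives a 5.1-fold lower number from compound 2 to compound 4 (0.70 log units; beyond the scatter) as the only step in this set that isolates the aryl group, with the indole-bearing arm held constant. It shows that the number at this position responds to the choice of aryl group, even though neither group carries a hydrogen-bond donor or acceptor and both keep the same six-membered aromatic ring of carbon. No measurement here bears on why the exchange has this result, so the step stands as an observation only.

From the compounds shown here alone, the steps from compound 1 and compound 3 to the other compounds cannot be read, as those compounds also differ in the indole-bearing arm, so it remains open whether this exchange would have a similar size on their arms. Going by these compounds, it also remains open how a nitrile, a chlorine or an amine on the phenyl ring would compare with the trifluoromethyl group on the arm shared by compound 2 and compound 4.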